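Moving the methyl around the benzyl ring of compound 2

This account rests on a few compounds, and the source may have more. Where it says the series, first, only, none or still open, it means among the compounds named here.

Measured compounds:
compound 1, `CCCN1CCC(c2noc(COc3ccc(/C=C/C(=O)NO)cc3)n2)CC1`: 69%
compound 2, `Cc1ccccc1CN1CCC(c2noc(COc3ccc(/C=C/C(=O)NO)cc3)n2)CC1`: 68%

In an assay on isolated protein for inhibition of protein deacetylase HDAC6 (Homo sapiens), read by fluorescence, with a stated time of 1 h, tested at 100 nM (on this read-out lower numbers stand for less inhibition and higher numbers for more inhibition at the one concentration tested (going by the name of the read-out)), compound 1 gives 69% and compound 2 gives 68%, the lowest of the two numbers, though the step of a number 1 percentage points lower from compound 1 to compound 2 (within the scatter) is within the scatter. Compound 3, `Cc1ccc(CN2CCC(c3noc(COc4ccc(/C=C/C(=O)NO)cc4)n3)CC2)cc1`, differs from compound 2 only as 4-methylphenyl in place of 2-methylphenyl on a saturated chain carbon bound to an amine nitrogen in a ring. Within the data shown here, no measured step moves a methyl around this aromatic ring; the one step known, a number 1 percentage points lower from compound 1 to compound 2 (within the scatter), exchanges whole groups at the same place and stays within the scatter. Compound 3 is therefore expected to show no step beyond the scatter, no change at the digits printed from compound 2 to compound 3 (within the scatter). The estimate for compound 3 is 68%, ranging from 55% to 80%.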

Compound 3, a percentage reported as inhibition, at one concentration (the size of the read-out at that concentration, not a potency): 76%
Compound 3: the middle estimate sits 8 percentage points below what was measured, and the stated range covers the measured number.
By their numbers in this assay, from the lowest: compounds 2, 1 and 3 (each within the scatter of the next).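

In this assay, among these compounds, shifting the methyl from 2-methylphenyl to 4-methylphenyl gives a number 8 percentage points higher from compound 2 to compound 3 (within the scatter), the first reading of where the methyl sits on this ring, while 4-methylphenyl in place of ethyl gives a number 7 percentage points higher from compound 1 to compound 3 (within the scatter). At this place, then, neither the methyl shift nor this exchange of whole groups has moved the number beyond the scatter. Nothing available explains these numbers.

From the compounds shown here alone, what stays open is whether a carboxylic acid or an amine on this ring, in place of the methyl, would give a step beyond the scatter. A longer chain in place of the benzyl group leaves the same question open.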